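Cycloheptyl to cyclohexylmethyl on the shared core

A few compounds are considered here, and "the series" means these few. Any claim that something is new, unique, unknown or untested is made for them only; others in the source may bear on it.

Measured in a functional assay on PC-3 cells (Homo sapiens) for cytotoxicity, read by WST assay, with a stated time of 72 h (on this read-out lower numbers stand for stronger inhibition and higher numbers for weaker inhibition), so far:
- compound 1 `CCOc1ccc(C2(c3ccc(O)cc3)C(=O)Nc3c2ccc(F)c3F)cc1` gives 24 nM
- compound 2 `O=C1Nc2c(ccc(F)c2F)C1(c1ccc(O)cc1)C1CCCCCC1` gives 12 nM

Compound 2 has only compound 1 for comparison, and the two values lie within the scatter of each other. Compound 3 `O=C1Nc2c(ccc(F)c2F)C1(CC1CCCCC1)c1ccc(O)cc1` carries cyclohexylmethyl in place of cycloheptyl on a saturated ring carbon. Within the data shown here, the one measured step, a 2.0-fold lower number from compound 1 to compound 2 (0.30 log units; within the scatter), replaced 4-ethoxyphenyl with cycloheptyl and stayed within the scatter. It does not test this exact change, but on that evidence no step beyond the scatter is expected in this assay. The expected change is a 1.7-fold higher number from compound 2 to compound 3 (0.22 log units; within the scatter), with no firm direction. Compound 3 is estimated at 20 nM, with an expected range of 7 nM to 60 nM.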

Compound 3, half-maximal inhibitory concentration: > 1000 nM
Compound 3: only a limit was reported; the forecaster's own chance of this, stated with the estimate: 1%; at least 50-fold (1.69 log units) between middle value and limit.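

In this assay, this saturated ring carbon is sensitive to the exact group it carries: cycloheptyl and cyclohexylmethyl have the same atoms, yet exchanging them gives an at least 83-fold higher number from compound 2 to compound 3 (1.92 log units; beyond the scatter). Replacing 4-ethoxyphenyl with cyclohexylmethyl likewise gives an at least 41-fold higher number from compound 1 to compound 3 (1.61 log units; beyond the scatter), although the exchange of 4-ethoxyphenyl for cycloheptyl stayed within the scatter. The result for compound 3 is a limit, not a number: the limit of > 1000 nM in this assay, at which 1 of the 3 values shown sits.

On these data alone, whether the six-membered ring or the attachment through a methylene carries this loss stays open. Cyclohexyl placed directly on this carbon would separate the two.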